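The compounds below may be only part of what the source reports. "The series", "measured", "known", "first", "only" and "open" are said of these compounds alone.

Three related compounds have been measured in a physicochemical assay for lipophilicity, read by HPLC, at pH 2 (a higher number here means a more lipophilic compound, a lower number a more polar compound), and their numbers spread widely. Compound 1 `CN(C)C(=O)[C@H]1CCC[C@@H](c2cccc(-n3ncc(C(=O)O)c3C3CC3)c2)C1` reads 1.7 here, compound 2 `CN(CC1CC1)C(=O)c1cccc(-c2cccc(-n3ncc(C(=O)O)c3C3CC3)c2)c1F` reads 2.2 and compound 3 `CCCC1CCCCN1C(=O)c1cccc(-c2cccc(-n3ncc(C(=O)O)c3C3CC3c3cccnc3)c2)c1` reads 3.9 at the top. Compound 2 therefore stands second highest of the three, and its gaps to the other two both lie beyond the scatter of repeated measurements.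

Compound 4 `O=C(O)c1cnn(-c2cccc(-c3cccc(C(=O)N(CC4CC4)CC4CC4)c3F)c2)c1C1CC1` has not yet been measured. It differs from compound 2 by cyclopropyl in place of hydrogen on a saturated chain carbon bound to an amide-type nitrogen and the change is cyclopropyl in place of hydrogen on a saturated chain carbon bound to an amide-type nitrogen, so that methyl becomes cyclopropylmethyl. For the measured compounds named here, no two measured compounds differ in one place only, so the data give no direct measure of such a step, and the expectation rests on the structural change alone. The expected step is a number 0.60 log units higher from compound 2 to compound 4 (beyond the scatter) and this estimated rise lies beyond the scatter. For compound 4 the expected value is 2.8 within a range of 2.4 to 3.2 as an estimate.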

Compound 4, distribution coefficient: 3.5
For compound 4 the middle estimate is 0.70 log units below the measured one; measured number outside the range, above it.
By their numbers in this assay, from the lowest: compound 1; then compound 2; then compound 4; then compound 3.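

In this assay, cyclopropyl in place of hydrogen on a saturated chain carbon bound to an amide-type nitrogen, which turns methyl into cyclopropylmethyl, gives a number 1.30 log units higher from compound 2 to compound 4 (beyond the scatter), a large step. For the compounds shown here, this is the only pair here that differs in one place, so it gives a direct reading of one change at this position, which the earlier compounds, differing in several places at once, could not give. Nothing available here accounts for the size of the step.

Going by these compounds, whether the same change gives a step of similar size on the dimethyl amide of compound 1 stays open. Also open, on these data alone, is how an isopropyl group or a longer chain ending in a hydroxyl group would read at this position in this assay.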